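Fluoro for nitro on the ketone-bearing aryl ring

The compounds below may be only part of what the source reports. "The series", "measured", "known", "first", "only" and "open" are said of these compounds alone.

Measured compounds:
- compound 1 `CCOC(=O)c1[nH]c(=O)c(C#N)cc1C(=O)c1ccc(C)cc1`: 512000 nM
- compound 2 `CCOC(=O)c1[nH]c(=O)c(C#N)cc1C(=O)c1ccc([N+](=O)[O-])cc1`: 213000 nM

In an ADME assay on L929 cells (Mus musculus) for cytotoxicity, read by MTT assay, with a stated time of 72 h (on this read-out lower numbers stand for higher toxicity in this test and higher numbers for lower toxicity in this test), compound 2 has the lowest of the two numbers; its nearest neighbour, compound 1, stands higher by a 2.4-fold lower number from compound 1 to compound 2 (0.38 log units; beyond the scatter). Compound 3 `CCOC(=O)c1[nH]c(=O)c(C#N)cc1C(=O)c1ccc(F)cc1` differs from compound 2 by fluoro in place of nitro on an aromatic carbon. Among the compounds with values here, the only measured step, from compound 1 to compound 2, concerns the same aromatic carbon and was modest. Since fluoro is a different group from both nitro and methyl, the number for compound 3 is expected to move back somewhat toward compound 1, by about a 1.6-fold higher number from compound 2 to compound 3 (0.22 log units; within the scatter), though it may also stay within the scatter. For compound 3 the estimated value in this assay is 350000 nM, with a range from 150000 nM to 800000 nM.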

Compound 3, half-maximal cytotoxic concentration: 232000 nM
Estimate against measurement, compound 3: 1.5-fold (0.18 log units) above; the range from low to high includes it.
By their numbers in this assay, from the lowest: compounds 2 and 3 (each within the scatter of the next); then compound 1.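

In this assay fluoro in place of nitro gives a 1.1-fold higher number from compound 2 to compound 3 (0.04 log units; within the scatter) and so the two groups cannot be told apart at this aromatic carbon, although fluoro has one heavy atom where nitro has three. Fluoro in place of methyl gives a 2.2-fold lower number from compound 1 to compound 3 (0.34 log units; beyond the scatter) and so, of the three groups, only the methyl of compound 1 reads apart from the others. No measurement at hand explains this result. Still open, as far as these compounds go, is how an amine or a carboxylic acid on this carbon would read, and whether an unsubstituted carbon here would read with methyl or with the other two.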